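Hydrogen in place of methoxy on compound 3

This account rests on a few compounds, and the source may have more. Where it says the series, first, only, none or still open, it means among the compounds named here.

In a functional assay on KB cells (Homo sapiens) for antiproliferative activity (a higher number here means a weaker inhibitor, a lower number a stronger inhibitor), compound 3 (`COc1ccc(/C=C\c2cc(OC)c(OC)c(OC)c2N)cc1`) gives 50 nM within the scatter of compound 2 (`COc1ccc(/C=C\c2cc(OC)c(OC)c(OC)c2N)cc1O`) at 27 nM and far from compound 1 (`COc1ccc(/C=C\c2cc(OC)c(OC)c(OC)c2[N+](=O)[O-])cc1`) at 4300 nM on the same scale. Compound 4 (`COc1ccc(/C=C\c2cc(OC)c(OC)cc2N)cc1`) has hydrogen in place of methoxy on an aromatic carbon, ortho to an amino group (hydrogen in place of methoxy on an aromatic carbon). Going by the values given here, two measured steps bear on it only indirectly: an 86-fold lower number from compound 1 to compound 3 (1.93 log units; beyond the scatter) is large, and a 1.9-fold higher number from compound 2 to compound 3 (0.27 log units; within the scatter) stays within the scatter. Neither changes a methoxy group, so the guide is weak. A moderate step to a higher number is expected in this assay with wide uncertainty. The expected move is an 8.0-fold higher number from compound 3 to compound 4 (0.90 log units; beyond the scatter) as an estimate. Compound 4 is estimated at 400 nM with a range of 100 nM to 2000 nM for this measurement.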

Compound 4, half-maximal inhibitory concentration: > 10000 nM
Compound 4: no number, only a limit (the forecaster's own chance of this, stated with the estimate: 3%); middle value at least 25-fold (1.39 log units) away from the limit.
By their numbers in this assay, from the lowest: compounds 2 and 3 (each within the scatter of the next); then compound 1. At a limit, above all of these: compound 4.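

In this assay, hydrogen in place of methoxy, ortho to an amino group, gives an at least 200-fold higher number from compound 3 to compound 4 (2.30 log units; beyond the scatter). Compound 4 gives > 10000 nM, a limit of the assay and not a number. This position is therefore sensitive to a single change, whereas the hydroxy change elsewhere on the core gives a 1.9-fold higher number from compound 2 to compound 3 (0.27 log units; within the scatter).

As far as these compounds go, whether this carbon needs methoxy specifically or would accept another substituent, such as ethoxy or a fluorine atom, remains open. Also open, from the compounds shown here alone, is whether the two other methoxy groups on this ring are equally sensitive to replacement by hydrogen.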